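A few compounds are considered here, and "the series" means these few. Any claim that something is new, unique, unknown or untested is made for them only; others in the source may bear on it.

Measured so far in an ADME assay on microsomes from liver (Mus musculus) for metabolic stability, using NADPH, with a stated time of 10 min; on this read-out higher numbers stand for a more stable compound and lower numbers for a less stable compound:
- compound 1 `CN(C[C@H]1Cc2c(cccc2N2CCC(N)CC2)CN1)[C@H]1CCCc2cccnc21`: 70.3%
- compound 2 `CN(C)[C@H]1CCN(c2cccc3c2C[C@H](CN(C)[C@H]2CCCc4cccnc42)NC3)C1`: 18.5%

Within the data shown here, compound 2 is the lower of the two, and the only measured step is a number 51.8 percentage points lower from compound 1 to compound 2 (beyond the scatter). Compound 3 `CN(C[C@H]1Cc2c(cccc2N[C@H]2CC[C@H](N)CC2)CN1)[C@H]1CCCc2cccnc21` differs from compound 2 as follows: (4-aminocyclohexyl)amino in place of 3-(dimethylamino)pyrrolidin-1-yl on an aromatic carbon. Among the measured compounds shown here, the measured step changed the group on the same aromatic carbon, so it is the only guide, and it is large. The entering group has a closer name match to the 4-aminopiperidin-1-yl of compound 1 (70.3%) than to the group it replaces. A large upward move is therefore expected, with the estimated step being a number 33.5 percentage points higher from compound 2 to compound 3 (beyond the scatter). Compound 3 is estimated at 52%, with an expected range of 25% to 80%.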

Compound 3, percent of the compound remaining: 100%
Compound 3: middle estimate off by 48 percentage points, on the low side; the measured number lies above the stated range.
By their numbers in this assay, from the lowest: compound 2; then compound 1; then compound 3.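

In this assay the read-out at this aromatic carbon responds to how the same atoms are joined: (4-aminocyclohexyl)amino in place of 3-(dimethylamino)pyrrolidin-1-yl gives a number 81.5 percentage points higher from compound 2 to compound 3 (beyond the scatter). In place of 4-aminopiperidin-1-yl the same group gives a number 29.7 percentage points higher from compound 1 to compound 3 (beyond the scatter), so a carbon-only ring on an amino link stands above both groups joined through a ring nitrogen. Nothing shown accounts for either step.

Still open, as far as these compounds go, is whether the link, the ring or the free primary amine carries the change. A 4-(dimethylamino)piperidin-1-yl group would separate the ring from the dimethylamino group.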